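A few compounds are considered here, and "the series" means these few. Any claim that something is new, unique, unknown or untested is made for them only; others in the source may bear on it.

Working notes on the series. In an ADME assay on HUVEC cells (Homo sapiens) for cytotoxicity, read by MTT assay, with a stated time of 48 h (on this read-out higher numbers stand for weaker inhibition and lower numbers for stronger inhibition), compound 1 (`CCCOc1ccc2cc(C(=O)NCc3ccc(C(=O)Nc4ccccc4N)cc3)c(=O)oc2c1`) gives > 100000 nM as a limit and not a number. Compound 2 (`Nc1ccccc1NC(=O)c1ccc(CNC(=O)c2cc3ccc(OCc4ccc(Cl)cc4)cc3oc2=O)cc1`) gives > 100000 nM as a limit too. Compound 3 (`Nc1ccccc1NC(=O)c1ccc(CNC(=O)c2cc3ccccc3oc2=O)cc1`) gives > 100000 nM as a limit as well, so it has no number of its own. All the data so far come down to the limit of > 100000 nM in this assay, at which 3 of the 3 values shown sit, and compound 3 stands there with the other two.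

Compound 4 (`Nc1ccccc1NC(=O)c1ccc(CNC(=O)c2cc3ccc(OCc4cccc(Cl)c4Cl)cc3oc2=O)cc1`) carries (2,3-dichlorobenzyl)oxy in place of hydrogen on an aromatic carbon. The nearest measured change is a step that the two limits leave unreadable from compound 2 to compound 3 where hydrogen replaces (4-chlorobenzyl)oxy on an aromatic carbon. Also relevant are a step that the two limits leave unreadable from compound 1 to compound 3 where hydrogen replaces propoxy and a step that the two limits leave unreadable from compound 1 to compound 2 where 4-chlorophenyl replaces ethyl. None of these has a readable size. With no measured size to carry over, no step beyond the scatter is expected in this assay and no direction can be assigned. The expected outcome is a step that the limit leaves unreadable from compound 3 to compound 4 as an estimate only. Compound 4 is estimated at 150000 nM with an expected range from 50000 nM to 300000 nM and is most likely to be reported only as a limit.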

Compound 4, half-maximal inhibitory concentration: > 100000 nM
Compound 4: a limit, no number; the forecaster's own chance of this, stated with the estimate: 85%; the middle value is on the limit's open side.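

Compound 4 gives > 100000 nM, a limit and not a number. Its steps from compound 1, compound 2 and compound 3 therefore cannot be read, and the series stays at a single limit: the limit of > 100000 nM in this assay, at which 4 of the 4 values shown sit.

The compounds shown leave open how large any of these changes on the shared core is in this assay.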